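Trading an aminomethyl-oxetane for a hydroxyethyl chain

This account rests on a few compounds, and the source may have more. Where it says the series, first, only, none or still open, it means among the compounds named here.

Compound 1, `CN1CCC(NC(=O)c2cc(-c3ccc(NS(=O)(=O)c4cccc(Cl)c4Cl)cc3)nc3[nH]ncc23)C1`, in an assay for inhibition of serine/threonine-protein kinase Sgk1 (Homo sapiens), with stated times of 30 min and 60 min, in the presence of a further agent that is not named here (a higher number here means a weaker inhibitor, a lower number a stronger inhibitor), gives < 1 nM, which is a limit of the assay rather than a number. Compound 2, `CNC(=O)c1cc(-c2ccc(NS(=O)(=O)c3cccc(Cl)c3Cl)cc2)nc2[nH]ncc12`, gives 4 nM. Compound 3, `Cc1n[nH]c2nc(-c3ccc(NS(=O)(=O)c4cc(Cl)ccc4F)cc3)nc(OCC3(CN)COC3)c12`, gives 1 nM.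

Among the two values that are numbers, compound 3 stands lowest, with compound 2 giving a higher number beyond the scatter; the third value is only a limit, (the limit of < 1 nM in this assay, at which 1 of the 3 values shown sits).

Compound 4, `Cc1n[nH]c2nc(-c3ccc(NS(=O)(=O)c4cc(Cl)ccc4F)cc3)nc(OCCCO)c12`, differs from compound 3 in one place: 2-hydroxyethyl in place of 3-(aminomethyl)oxetan-3-yl on a saturated chain carbon bound to an oxygen on an aromatic ring. Within the data shown here, no measured pair shows exactly this change. Among the measured compounds shown here, the only measured step, an at least 4.0-fold higher number from compound 1 to compound 2 (0.60 log units; beyond the scatter), also trimmed a larger ring-bearing group down to a small one, at a different place on a different core, and it weakened inhibition by at least a modest amount. On that thin basis, a modest weakening is expected here too, a 4.0-fold higher number from compound 3 to compound 4 (0.60 log units; beyond the scatter). Compound 4 is therefore estimated at 4 nM, with a likely range from 1 nM to 15 nM.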

Compound 4, half-maximal inhibitory concentration: 2 nM
For compound 4 the middle estimate is 2.0-fold (0.30 log units) above the measured one, within the range that was stated.
By their numbers in this assay, from the lowest: compounds 3, 4 and 2 (each within the scatter of the next, the first and the last beyond it).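

Swapping the group at this place gives a 2.0-fold higher number from compound 3 to compound 4 (0.30 log units; within the scatter), so compound 3 and compound 4 cannot be told apart in this assay. The nitrogen and the four-membered ring of 3-(aminomethyl)oxetan-3-yl are therefore not required at this place for a value in this range, since 2-hydroxyethyl carries neither. Compound 1 stands at a limit of the assay rather than at a number, and the values here lie so close to it that little room remains to see small differences: the limit of < 1 nM in this assay, at which 1 of the 4 values shown sits.

Still open, going by these compounds, is how a carboxylic acid, a simple primary amine or a longer chain ending in a hydroxyl would read at this place. The same swap on the core of compound 2 is also untested by these compounds, so the result cannot be carried over to it.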